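Compound 3 and a Larger Ether at the Chain Carbon

The source may hold more compounds than are shown below. What is called first, only, known or untested is meant among the compounds shown, and "the series" means these compounds.

Compound 3 `CO/N=C(/c1ccc(Cl)cc1)C(CN1CCN(c2ccccn2)CC1)OC` gives 285 nM in a functional assay on HEK293 cells with D(4) dopamine receptor (Homo sapiens) as the target, read by FLIPR (on this read-out lower numbers stand for an effect already at smaller amounts and higher numbers for an effect only at larger amounts of compound), the highest of the three numbers shown. Compound 1 `CO/N=C(\CCN1CCN(c2ccccn2)CC1)c1ccc(Cl)cc1` gives 37.6 nM, and compound 2 `CO/N=C(/c1ccc(Cl)cc1)C(O)CN1CCN(c2ccccn2)CC1` gives 22.6 nM. Compound 4 `CO/N=C(/c1ccc(Cl)cc1)C(COC(C)C)CN1CCN(c2ccccn2)CC1` carries the change (isopropoxymethyl in place of methoxy on a saturated chain carbon bound to a carbon with a double bond to nitrogen and a saturated chain carbon). Within the data shown here, two measured steps bear on this position: a 7.6-fold higher number from compound 1 to compound 3 (0.88 log units; beyond the scatter) and a 13-fold higher number from compound 2 to compound 3 (1.10 log units; beyond the scatter). Both show a higher number once an ether group sits at this place instead of hydrogen or hydroxy, and the larger isopropoxymethyl group keeps an ether there. The step from compound 3 to compound 4 in this assay is therefore expected to be a 1.4-fold higher number from compound 3 to compound 4 (0.15 log units; within the scatter), a further rise or none beyond the scatter. Compound 4 is expected to give 400 nM, within 90 nM to 1800 nM.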

Compound 4, half-maximal effective concentration: 3210 nM
Compound 4: middle estimate off by 8.0-fold (0.90 log units), on the low side; the whole stated range lies below it.
By their numbers in this assay, from the lowest: compounds 2 and 1 (each within the scatter of the next); then compound 3; then compound 4.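

Isopropoxymethyl in place of methoxy on this saturated chain carbon gives an 11-fold higher number from compound 3 to compound 4 (1.05 log units; beyond the scatter) even though both groups are ethers with the same hydrogen-bond acceptor count, so having an ether at this place does not by itself fix the number. The gaps to the compounds without an ether are wider still, with a 140-fold higher number from compound 2 to compound 4 (2.15 log units; beyond the scatter) and an 85-fold higher number from compound 1 to compound 4 (1.93 log units; beyond the scatter) on record. Nothing measured here accounts for this rise. The compounds shown leave open whether the rise follows the branched isopropyl end or the added carbon before the oxygen; methoxymethyl at this carbon would help separate the two.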